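A few compounds are considered here, and "the series" means these few. Any claim that something is new, unique, unknown or untested is made for them only; others in the source may bear on it.

Measured compounds:
- compound 1, `CC(C)(C)C1=NN(c2cccc(Cl)c2)C(c2ccc(O)cc2)C1`, 5200 nM
- compound 2, `CC(C)(C)C1=NN(c2c(Cl)cccc2Cl)C(c2ccc(O)cc2)C1`, "not determined" (no result reported)
- compound 3, `Oc1ccc(C2CC(c3ccccc3)=NN2c2ccc(Cl)cc2)cc1`, 3500 nM

The read-out is an assay on isolated protein for inhibition of protein kinase C zeta type (Homo sapiens), with a stated time of 4 min; on this read-out lower numbers stand for stronger inhibition and higher numbers for weaker inhibition. Among the two numbers shown, compound 3 gives the lower one, yet its separation from compound 1 lies within the scatter, so no order between the two can be claimed. Compound 4, `Oc1ccc(C2CC(c3ccccc3)=NN2c2cccc(Cl)c2)cc1`, has not been measured. It differs from compound 3 in one place: 3-chlorophenyl in place of 4-chlorophenyl on an amine nitrogen in a ring. Among the measured compounds shown here, no step between measured compounds with exactly this change is available, so the estimate rests on the spread of the two numbers, which suggests nothing beyond the scatter in either direction. Compound 4 is therefore expected at 4500 nM, within 1500 nM to 13000 nM, a step of a 1.3-fold higher number from compound 3 to compound 4 (0.11 log units; within the scatter) that is expected to remain within the scatter.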

Compound 4, half-maximal inhibitory concentration: 2100 nM
Estimate against measurement, compound 4: 2.1-fold (0.33 log units) above, within the range that was stated.
By their numbers in this assay, from the lowest: compounds 4, 3 and 1 (each within the scatter of the next, the first and the last beyond it).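

In this assay, 3-chlorophenyl in place of 4-chlorophenyl on the amine nitrogen in the ring gives a 1.7-fold lower number from compound 3 to compound 4 (0.22 log units; within the scatter), so this read-out does not separate the two groups at this position. Phenyl in place of tert-butyl on the carbon with a double bond to nitrogen gives a 2.5-fold lower number from compound 1 to compound 4 (0.39 log units; beyond the scatter), the first single-place step here that lies beyond the scatter, though a modest one. Nothing measured explains either step. Going by these compounds, what an amine or a carboxylic acid in place of the chlorine would do remains open, as does a longer chain in place of that phenyl.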